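The compounds below may be only part of what the source reports. "The series", "measured", "known", "first", "only" and "open" are said of these compounds alone.

In an assay on cells for antagonist activity at transient receptor potential cation channel subfamily V member 1 (Homo sapiens), read by FLIPR and calcium flux, with a stated time of 6 min (on this read-out higher numbers stand for weaker inhibition and lower numbers for stronger inhibition), compound 1 `CC(C(=O)NCc1ccc(C(C)(C)C)nc1N1CCCCCC1)c1ccc(NS(C)(=O)=O)c(F)c1` gives 0.9 nM, compound 2 `CCCOc1nc(C(C)(C)C)ccc1CNC(=O)C(C)c1ccc(NS(C)(=O)=O)c(F)c1` gives 1.7 nM, and compound 3 `CC(C)COc1nc(C(C)(C)C)ccc1CNC(=O)C(C)c1ccc(NS(C)(=O)=O)c(F)c1` gives 0.6 nM. Compound 3 thus holds the lowest of the three numbers; its gap to compound 1 is within the scatter, and only its gap to compound 2 is beyond it. For the measured compounds named here, the three compounds differ at a single aromatic carbon of the shared core. a 1.9-fold higher number from compound 1 to compound 2 (0.28 log units; within the scatter) and a 1.5-fold lower number from compound 1 to compound 3 (0.18 log units; within the scatter) both stay within the scatter, while a 2.8-fold lower number from compound 2 to compound 3 (0.45 log units; beyond the scatter) is the one modest step among them, so exchanging the group at that carbon has so far moved the numbers little.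

Compound 4 `CCCCSc1nc(C(C)(C)C)ccc1CNC(=O)C(C)c1ccc(NS(C)(=O)=O)c(F)c1` continues at the same carbon: butylsulfanyl in place of isobutoxy on an aromatic carbon. Going by the values given here, none of the measured steps exchanges an oxygen for a sulfur at this position, so the data say nothing directly about that exchange. What they do show is that three different groups at this carbon gave numbers spread over a narrow range. On that basis compound 4 is expected to show a 2.0-fold higher number from compound 3 to compound 4 (0.30 log units; within the scatter) in this assay, nothing beyond the scatter. The estimate for compound 4 is 1.2 nM, with a range from 0.4 nM to 4 nM.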

Compound 4, inhibition constant: 3.2 nM
Estimate against measurement, compound 4: 2.7-fold (0.43 log units) below; the measured number falls inside the stated range.
By their numbers in this assay, from the lowest: compounds 3, 1, 2 and 4 (each within the scatter of the next, the first and the last beyond it).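

In this assay, for the compounds shown here, this carbon proves less tolerant than the earlier compounds suggested, as butylsulfanyl gives a 5.3-fold higher number from compound 3 to compound 4 (0.73 log units; beyond the scatter) and so the largest step yet seen at this position, and a 3.6-fold higher number from compound 1 to compound 4 (0.55 log units; beyond the scatter) also lies beyond the scatter, while a 1.9-fold higher number from compound 2 to compound 4 (0.27 log units; within the scatter) does not. Going by these compounds alone, the outcome therefore depends on which group butylsulfanyl replaces, and the straight-chain propoxy of compound 2 is the only earlier group that stays within the scatter of it. The step from isobutoxy also changes two things at once, oxygen to sulfur and a branched chain to a straight one, and nothing available explains why any of these steps has its size.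

The compounds shown leave open whether the sulfur or the straight chain carries the step from compound 3, a question that butoxy or isobutylsulfanyl at the same carbon would separate. They also leave open how an amine other than azepan-1-yl, such as pyrrolidin-1-yl or a simple dimethylamino group, would compare at this carbon.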